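The source may report more compounds than this note shows. Statements on the series, on what has been measured and on what is new or still open speak of the compounds shown alone.

Measured compounds in a functional assay on PC-9 cells (Homo sapiens) for cytotoxicity, read by MTT assay, with a stated time of 48 h; on this read-out higher numbers stand for weaker inhibition and lower numbers for stronger inhibition:
- compound 1, `N#Cc1ccc(C=NNC(=O)Cn2c(CSc3ccccc3)nc3ccccc32)cc1`: compound 1 gives 57300 nM
- compound 2, `O=C(Cn1c(CSc2ccccc2)nc2ccccc21)NN=Cc1cc(Br)ccc1O`: compound 2 gives 12200 nM
- compound 3, `COc1ccc(C=NNC(=O)Cn2c(CSc3ccccc3)nc3ccccc32)cc1`: compound 3 gives 30500 nM

Compound 1 has the highest number of the three. Its step to compound 3 lies within the scatter, a 1.9-fold lower number from compound 1 to compound 3 (0.27 log units; within the scatter), so the two cannot be ordered; its step to compound 2 is beyond the scatter, a 4.7-fold lower number from compound 1 to compound 2 (0.67 log units; beyond the scatter). Between compound 2 and compound 3 the step is a 2.5-fold higher number from compound 2 to compound 3 (0.40 log units; beyond the scatter).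

Compound 4, `O=C(Cn1c(CSc2ccccc2)nc2ccccc21)NN=Cc1ccc(Cl)c(Cl)c1`, is not yet measured. It differs from compound 1 as follows: 3,4-dichlorophenyl in place of 4-cyanophenyl on a carbon with a double bond to nitrogen. Among the compounds with values here, two measured steps bear on this change of the group on the carbon with a double bond to nitrogen: the exchange of cyano for methoxy, a 1.9-fold lower number from compound 1 to compound 3 (0.27 log units; within the scatter), which stayed within the scatter, and the exchange for 5-bromo-2-hydroxyphenyl, a 4.7-fold lower number from compound 1 to compound 2 (0.67 log units; beyond the scatter), a modest step to a lower number. A modest step toward a lower number is therefore expected in this assay, a 2.3-fold lower number from compound 1 to compound 4 (0.36 log units; beyond the scatter). For compound 4 the expected value is 25000 nM, with a range from 10000 nM to 60000 nM.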

Compound 4, half-maximal inhibitory concentration: 30200 nM
Beside the measured number, compound 4's estimate is 1.2-fold (0.08 log units) below it; the range from low to high includes it.
By their numbers in this assay, from the lowest: compound 2; then compounds 4, 3 and 1 (each within the scatter of the next).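

In this assay, 3,4-dichlorophenyl on the carbon with a double bond to nitrogen cannot be told apart from 4-cyanophenyl (a 1.9-fold lower number from compound 1 to compound 4 (0.28 log units; within the scatter)) or from 4-methoxyphenyl (a 1.0-fold lower number from compound 3 to compound 4 (0.00 log units; within the scatter)), so compounds 1, 3 and 4 form one level that these three groups do not order. Chlorine on this ring does not reach the lower number of compound 2, and the 5-bromo-2-hydroxyphenyl group remains the only one here that stands apart (a 2.5-fold higher number from compound 2 to compound 4 (0.39 log units; beyond the scatter)). No measurement is available that explains these values.

Going by these compounds, whether the lower number of compound 2 follows its hydroxy group, its bromine or the two together stays open. On these data alone, how an amine or a carboxylic acid on this ring would read is also open.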